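The source may report more compounds than this note shows. Statements on the series, on what has been measured and on what is new or still open speak of the compounds shown alone.

In a functional assay on HCT-116 cells (Homo sapiens) for inhibition, read by CCK-8 assay, with a stated time of 72 h, tested at 2 uM (on this read-out lower numbers stand for less inhibition of growth and higher numbers for more inhibition of growth at the one concentration tested), two compounds sharing the same core have been measured so far. Compound 1 `Nc1ccccc1NC(=O)/C=C/c1ccc(CSc2ccc(Cl)cc2)cc1` gives 5.62%, and compound 2 `CCc1ccc(SCc2ccc(/C=C/C(=O)Nc3ccccc3N)cc2)cc1` gives 3.29%. These two numbers lie within the scatter of each other, so compound 2 stands level with compound 1, and both show little inhibition of growth. Compound 3 `Cc1ccc(SCc2ccc(/C=C/C(=O)Nc3ccccc3N)cc2)cc1` differs from compound 2 in one place: hydrogen in place of methyl on a saturated chain carbon bound to an aromatic carbon. Here hydrogen replaces methyl on a saturated chain carbon bound to an aromatic carbon, turning 4-ethylphenyl into 4-methylphenyl. Going by the values given here, the only measured step that bears on this is ethyl in place of chloro on an aromatic carbon, a number 2.3 percentage points lower from compound 1 to compound 2 (within the scatter). That step stayed within the scatter, so no shift beyond the scatter, in either direction, is expected in this assay. The expected change is a number 0.7 percentage points higher from compound 2 to compound 3 (within the scatter). For compound 3 the estimate is 4%, with an expected range of -2% to 12%.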

Compound 3, percent growth inhibition at one concentration: 6.23%
For compound 3 the middle estimate is 2.2 percentage points below the measured one; the measured number falls inside the stated range.
By their numbers in this assay, from the lowest: compounds 2, 1 and 3 (each within the scatter of the next).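

In this assay the change from ethyl to methyl gives a number 2.9 percentage points higher from compound 2 to compound 3 (within the scatter) and so adds a second small alkyl group to the comparison, and trimming this chain by one carbon does not move the read-out beyond the usual scatter. Methyl in place of chloro on an aromatic carbon gives a number 0.6 percentage points higher from compound 1 to compound 3 (within the scatter) and so shows that chloro, ethyl and methyl all stand level here, each with little inhibition of growth at the one concentration tested. No measurement shown here explains why these groups read alike.

As far as these compounds go, it remains open whether an amine or a carboxylic acid on this aromatic carbon would shift the number beyond the scatter. From the compounds shown here alone, a longer chain, such as butyl, is equally open.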